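This account rests on a few compounds, and the source may have more. Where it says the series, first, only, none or still open, it means among the compounds named here.

Three carbamates sharing the core of compound 1 `CC(C)(C)c1ccc(COC(=O)N[C@H]2CNC2=O)cc1` have been measured in an assay on HEK293 cells for inhibition of N-acylethanolamine-hydrolyzing acid amidase (Homo sapiens), read by fluorescence, with stated times of 10 min and 50 min; a higher number here means a weaker inhibitor, a lower number a stronger inhibitor. Compound 1 gives 310 nM. Compound 3 `COc1ccc(CCCCOC(=O)N[C@H]2CNC2=O)cc1` gives 520 nM, a number within the scatter of that of compound 1, so the two cannot be told apart. Compound 2 `O=C(N[C@H]1CNC1=O)OCCCCCC1CCCCC1` gives 49 nM, a lower number that lies beyond the scatter, which leaves compound 1 second highest of the three in this assay. The next compound, compound 4 `CCc1ccc(COC(=O)N[C@H]2CNC2=O)cc1`, differs from compound 1 in one place: ethyl in place of tert-butyl on an aromatic carbon. Going by the values given here, the three measured compounds differ from one another at more than one place, so no measured pair isolates this exchange, and its effect in this assay can only be estimated from the general spread seen so far. The expected step is a 1.9-fold higher number from compound 1 to compound 4 (0.29 log units; within the scatter), a modest rise that may well remain inside the scatter. Compound 4 is estimated at 600 nM, with a range from 200 nM to 2000 nM.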

Compound 4, half-maximal inhibitory concentration: 160 nM
For compound 4 the middle estimate is 3.8-fold (0.57 log units) above the measured one, outside the stated range (below it).
By their numbers in this assay, from the lowest: compound 2; then compounds 4, 1 and 3 (each within the scatter of the next, the first and the last beyond it).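

Going by these compounds alone, the first measured single-place exchange at this aromatic carbon, para to a large group, gives a 1.9-fold lower number from compound 1 to compound 4 (0.29 log units; within the scatter) in this assay, so compound 1 and compound 4 cannot be told apart. At this position, then, tert-butyl with its 4 heavy atoms and ethyl with its 2 are not distinguished by this measurement, and the tert-butyl group's full size is not shown to be needed for a number of this order. No measured evidence is at hand that bears on how this exchange acts on the enzyme.

Going by these compounds, whether the same aromatic carbon would give a similar number with plain hydrogen, a chlorine atom, an amine or a carboxylic acid stays open. So does the effect of a longer chain there, such as n-butyl or n-hexyl, in place of ethyl.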